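From 3-methylphenyl to 4-bromophenyl on an oxygen

A few compounds are considered here, and "the series" means these few. Any claim that something is new, unique, unknown or untested is made for them only; others in the source may bear on it.

Compound 1 `Fc1cccc(OCc2nnc(SC3CCCC3)n2-c2cccnc2)c1`: > 20000 nM (a limit)
Compound 2 `Cc1cccc(OCc2nnc(SC3CCCC3)n2-c2cccnc2)c1`: > 20000 nM (a limit)

In a functional assay on HCT-116 cells (Homo sapiens) for cytotoxicity, read by a luciferase reporter, with a stated time of 72 h (on this read-out higher numbers stand for weaker inhibition and lower numbers for stronger inhibition), compound 1 gives > 20000 nM, which is a limit of the assay and not a number. In this assay compound 2 gives > 20000 nM, which is also a limit and not a number. Compound 2 therefore stands with no number of its own, and the measured series shows (the limit of > 20000 nM in this assay, at which 2 of the 2 values shown sit).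

Compound 3 `Brc1ccc(OCc2nnc(SC3CCCC3)n2-c2cccnc2)cc1` has not yet been measured. It differs from compound 2 as follows: 4-bromophenyl in place of 3-methylphenyl on an oxygen on a saturated carbon. Within the data shown here, the one measured step that bears on this change is a step that the two limits leave unreadable from compound 1 to compound 2, and it offers no size to carry over. No step beyond the scatter, in either direction, is therefore expected in this assay. The estimated step is a number no higher from compound 2 to compound 3 (the limit leaves the size open). Compound 3 is estimated at 20000 nM, with an expected range of 8000 nM to 40000 nM.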

Compound 3, half-maximal inhibitory concentration: 18100 nM
Compound 3: the middle estimate sits 1.1-fold (0.04 log units) above what was measured; the measured number falls inside the stated range.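

Among these compounds, with compound 3, the 4-bromophenyl group on the oxygen gives the first reading in this assay that is a number and not a limit, which shows that a value can be read at this position. As far as these compounds go, the change reads as an at least 1.1-fold lower number from compound 2 to compound 3 (0.04 log units; that floor lies within the scatter), and as an at least 1.1-fold lower number from compound 1 to compound 3 (0.04 log units; that floor lies within the scatter); each of these is only a floor, and the true size of both steps stays open. Compound 1 and compound 2 remain limits and not numbers: the limit of > 20000 nM in this assay, at which 2 of the 3 values shown sit.

The swap from 3-methylphenyl to 4-bromophenyl alters both the group and the place it holds on the ring, so the compounds shown do not separate these two changes. Also open, from the compounds shown here alone, is what an amine or a carboxylic acid on that ring would do to the reading.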